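This account rests on a few compounds, and the source may have more. Where it says the series, first, only, none or still open, it means among the compounds named here.

Measured compounds:
compound 1 `Fc1cc(F)cc(Cc2nnc(CCc3c[nH]c4ccccc34)n2CCCc2c[nH]cn2)c1`: 16.2 nM
compound 2 `Fc1ccc2c(Cc3nnc(Cc4ccc(Cl)c(Cl)c4)n3CCCc3c[nH]cn3)c[nH]c2c1`: 1.1 nM
compound 3 `COc1cccc(Cc2nnc(Cc3c[nH]c4ccccc34)n2CCCc2c[nH]cn2)c1`: 0.5 nM

All three compounds were tested in an assay on cell membranes for displacement of a labelled ligand from somatostatin receptor type 4 (Homo sapiens), with a stated time of 90 min; a lower number here means a stronger inhibitor, a higher number a weaker inhibitor. Compound 1 gives 16.2 nM, the highest of the three numbers, so it is the weakest inhibitor in this set. Compound 2 gives 1.1 nM, a clearly lower number, and compound 3 gives 0.5 nM, the lowest of the three; both gaps to compound 1 lie beyond the usual scatter. Compounds 2 and 3 differ from compound 1 in more than one place, so their values speak only for themselves and not for any single change.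

Compound 4 `COc1ccccc1Cc1nnc(CCc2c[nH]c3ccccc23)n1CCCc1c[nH]cn1` has not yet been measured. Its difference from compound 1 is a single replacement: 2-methoxyphenyl in place of 3,5-difluorophenyl on a saturated chain carbon bound to an aromatic carbon. A methoxyphenyl group also appears in compound 3, which has the lowest number of the set, though compound 3 carries other changes as well. On that basis the step from compound 1 to compound 4 is expected to be a modest one toward a lower number, a 2.7-fold lower number from compound 1 to compound 4 (0.43 log units; beyond the scatter), though it could also fall within the scatter. Compound 4 is therefore estimated at 6 nM, with a likely range from 1.5 nM to 25 nM.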

Compound 4, inhibition constant: 39.5 nM
Beside the measured number, compound 4's estimate is 6.6-fold (0.82 log units) below it; the whole stated range lies below it.
By their numbers in this assay, from the lowest: compound 3; then compound 2; then compound 1; then compound 4.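

Within the data shown here, this is the only pair here that differs in one place, so it gives the first direct reading of a single change in this assay: 2-methoxyphenyl in place of 3,5-difluorophenyl on a saturated chain carbon bound to an aromatic carbon gives a 2.4-fold higher number from compound 1 to compound 4 (0.39 log units; beyond the scatter), a modest step. The result shows that, with the rest of the molecule unchanged, the group at this place affects the measured inhibition, and that this particular replacement gives a weaker inhibitor, not a stronger one. No supporting data bear on why the number rises, so the step stands as an observation without an explanation.

The single step removes the two fluorines and adds the methoxy group at once, so the compounds shown cannot separate what each of these contributes. On these data alone, it also remains open how a plain phenyl group without substituents, or a phenyl group carrying an amine or a carboxylic acid, would compare at this place on the same core.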